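Acylurea thiazole hydrazones: swapping the difluorophenyl pattern

A few compounds are considered here, and "the series" means these few. Any claim that something is new, unique, unknown or untested is made for them only; others in the source may bear on it.

Measured compounds, with their half-maximal inhibitory concentration in a functional assay on HepG2 cells (Homo sapiens) for inhibition, read by MTT assay, with a stated time of 72 h; on this read-out higher numbers stand for weaker inhibition and lower numbers for stronger inhibition:
compound 1 `CN(C(=O)NC(=O)c1ccc(F)c(F)c1)c1nc(C(F)(F)F)c(C(=O)N/N=C/c2ccc([N+](=O)[O-])cc2)s1` gives 6.23 ug/mL;
compound 2 `CN(C(=O)NC(=O)c1c(F)cccc1F)c1nc(C(F)(F)F)c(C(=O)N/N=C/c2cc(C(F)(F)F)cc(C(F)(F)F)c2)s1` gives 6.28 ug/mL;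
compound 3 `CN(C(=O)NC(=O)c1ccc(F)c(F)c1)c1nc(C(F)(F)F)c(C(=O)N/N=C/c2cccc(C(F)(F)F)c2)s1` gives 5.6 ug/mL.

Compound 3 has the lowest number of the three, but its nearest neighbour compound 1 and its furthest neighbour compound 2 both sit within the scatter of it, so no order among the three can be read. Among the measured compounds shown here, the one single-point step in the set, a 1.1-fold lower number from compound 1 to compound 3 (0.05 log units; within the scatter), is likewise within the scatter.

Compound 4 `CN(C(=O)NC(=O)c1c(F)cccc1F)c1nc(C(F)(F)F)c(C(=O)N/N=C/c2cccc(C(F)(F)F)c2)s1` keeps the 3-(trifluoromethyl)phenyl hydrazone of compound 3 and changes only the acyl part: 2,6-difluorophenyl in place of 3,4-difluorophenyl on a carbonyl carbon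

For the measured compounds named here, no measured pair isolates this change. Compound 2 carries the same 2,6-difluorophenyl on the carbonyl carbon, but differs from compound 1 in two places, and both give values within the scatter of compound 3. The bearing evidence therefore points to no step beyond the scatter, in either direction.

Compound 4 is expected to give 5.9 ug/mL in this assay, with a range from 3 ug/mL to 11.5 ug/mL; the expected step is a 1.1-fold higher number from compound 3 to compound 4 (0.02 log units; within the scatter).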

Compound 4, half-maximal inhibitory concentration: 27.9 ug/mL
For compound 4 the middle estimate is 4.7-fold (0.67 log units) below the measured one, and the stated range ends below it.
By their numbers in this assay, from the lowest: compounds 3, 1 and 2 (each within the scatter of the next); then compound 4.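

In this assay, among the compounds shown here, the aryl group on a carbonyl carbon is not indifferent: 2,6-difluorophenyl in place of 3,4-difluorophenyl gives a 5.0-fold higher number from compound 3 to compound 4 (0.70 log units; beyond the scatter) as the first single-point step in the set beyond the scatter. With 2,6-difluorophenyl held fixed, the hydrazone side also registers, and hydrogen in place of trifluoromethyl on an aromatic carbon gives a 4.4-fold higher number from compound 2 to compound 4 (0.65 log units; beyond the scatter) as a second such step. Nothing measured here explains either step.

Open, going by these compounds, is whether the 3,4-difluorophenyl and 2,6-difluorophenyl groups would differ to the same extent on other hydrazones, since each of these two steps rests on a single pair. Also open, on these data alone, is how an amine or a carboxylic acid on the aryl group at the carbonyl carbon would read in this assay against these difluorophenyl groups.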